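Moving a methyl group around the benzoyl ring

A few compounds are considered here, and "the series" means these few. Any claim that something is new, unique, unknown or untested is made for them only; others in the source may bear on it.

Three compounds share one core carrying two ester groups. Compound 1 `CC(=O)Oc1ccccc1C(=O)O[C@H]1CO[C@H]2[C@@H]1OC[C@H]2OC(=O)c1ccnn1C` gives a half-life of 0.0963 h in an ADME assay on a cell-free system (plasma, Homo sapiens) for metabolic stability, with Plasma (Rattus norvegicus) as the target, read by HPLC, at pH 7.4; on this read-out higher numbers stand for a longer-lived compound and lower numbers for a shorter-lived compound. Compound 2 `CCC(=O)O[C@@H]1CO[C@H]2[C@@H]1OC[C@@H]2OC(=O)c1ccccc1OC(C)=O` gives 0.0608 h in this assay. Compound 3 `CC(=O)Oc1ccccc1C(=O)O[C@H]1CO[C@H]2[C@@H]1OC[C@H]2OC(=O)c1cccc(C)c1` gives 0.165 h in this assay. Compound 3 is set apart from compound 2 by a 2.7-fold higher number from compound 2 to compound 3 (0.43 log units; beyond the scatter), whereas a 1.7-fold higher number from compound 1 to compound 3 (0.23 log units; within the scatter), so compound 3 and compound 1 cannot be told apart on this read-out. The step from compound 1 to compound 2 is also small: a 1.6-fold lower number from compound 1 to compound 2 (0.20 log units; within the scatter).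

Compound 4 `CC(=O)Oc1ccccc1C(=O)O[C@H]1CO[C@H]2[C@@H]1OC[C@H]2OC(=O)c1ccc(C)cc1` differs from compound 3 only in this way: 4-methylphenyl in place of 3-methylphenyl on a carbonyl carbon. Within the data shown here, none of the measured steps swaps one methylphenyl for another; each of them exchanges the whole group on that carbonyl carbon, and even those larger exchanges moved the half-life only modestly. Compound 4 is therefore expected to sit close to compound 3, with no change at the digits printed from compound 3 to compound 4 (within the scatter), a step within the scatter. The estimate for compound 4 in this assay is 0.165 h, in a range from 0.08 h to 0.34 h.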

Compound 4, half-life: 0.105 h
For compound 4 the middle estimate is 1.6-fold (0.20 log units) above the measured one, and the stated range covers the measured number.
By their numbers in this assay, from the lowest: compounds 2, 1, 4 and 3 (each within the scatter of the next, the first and the last beyond it).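

Swapping 3-methylphenyl for 4-methylphenyl on this carbonyl carbon joins the same atoms differently, and in this assay this one exchange of a methylphenyl for another stays within the scatter (a 1.6-fold lower number from compound 3 to compound 4 (0.20 log units; within the scatter)). Compound 4 also cannot be told apart from the compounds carrying ethyl (a 1.7-fold higher number from compound 2 to compound 4 (0.24 log units; within the scatter)) or 1-methyl-1H-pyrazol-5-yl (a 1.1-fold higher number from compound 1 to compound 4 (0.04 log units; within the scatter)), so the clear separation from compound 2 seen with 3-methylphenyl does not carry over to 4-methylphenyl. Nothing available explains these half-lives.

The compounds shown leave open how the half-life would respond if this carbonyl carbon carried a longer chain or a ring bearing an amine or a carboxylic acid. They also leave open what a change to the other ester on the shared core would do.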